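A Trifluoromethyl Swap in a Weakly Antiproliferative Series

A few compounds are considered here, and "the series" means these few. Any claim that something is new, unique, unknown or untested is made for them only; others in the source may bear on it.

Compound 3 `CCc1cc(=O)c2ccc(OCc3cccc(C)c3)c(C)c2o1` holds the highest of the two numbers reported in a functional assay on KBVIN cells (Homo sapiens) for antiproliferative activity, read by sulforhodamine B assay, with a stated time of 72 h (on this read-out higher numbers stand for weaker inhibition of growth and lower numbers for stronger inhibition of growth), where compound 3 gives 24900 nM. Compound 2 `CCc1cc(=O)c2ccc(OCc3ccccc3)c(C)c2o1` gives 24800 nM in this assay. The single-point step a 1.0-fold higher number from compound 2 to compound 3 (0.00 log units; within the scatter) therefore shows nothing beyond the scatter. Compound 1 `COc1ccc(Br)c(CSc2ccc3c(C)cc(=O)oc3c2)c1` reaches only a limit in this assay, > 25500 nM, as noted in the limit of > 25500 nM in this assay, at which 1 of the 3 values shown sits.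

Compound 4 `CCc1cc(=O)c2ccc(OCc3cccc(C(F)(F)F)c3)c(C)c2o1` differs from compound 3 by trifluoromethyl in place of methyl on an aromatic carbon. For the measured compounds named here, the only measured step at this position, a 1.0-fold higher number from compound 2 to compound 3 (0.00 log units; within the scatter), was flat, and no measured step covers a trifluoromethyl directly. The expectation is accordingly a step of a 1.0-fold higher number from compound 3 to compound 4 (0.00 log units; within the scatter) with no direction beyond the scatter. Compound 4 is estimated at 25000 nM, with a range from 12000 nM to 52000 nM.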

Compound 4, concentration for 50% growth inhibition: > 27600 nM
Compound 4: a limit, no number (the forecaster's own chance of this, stated with the estimate: 40%); middle value at least 1.1-fold (0.04 log units) from the limit.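

In this assay compound 4 gives a limit and not a number, the first at this position: the limit of > 27600 nM in this assay, at which 1 of the 4 values shown sits. Trifluoromethyl therefore brought no stronger inhibition of growth here, since the result is an at least 1.1-fold higher number from compound 3 to compound 4 (0.04 log units; that floor lies within the scatter) and also an at least 1.1-fold higher number from compound 2 to compound 4 (0.04 log units; that floor lies within the scatter). Both floors stay within the scatter, and the limit sets no upper end to either step.

The compounds shown leave open whether an amine or a carboxylic acid on this aromatic carbon would give a measurable number. They also leave open whether a longer chain elsewhere on the shared core would do so.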